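Malonamide esters as intestinal acyl-CoA:cholesterol acyltransferase inhibitors

The source may report more compounds than this note shows. Statements on the series, on what has been measured and on what is new or still open speak of the compounds shown alone.

Measured compounds:
compound 1, `CCCCCCCCCCC(C)OC(=O)CC(=O)Nc1c(C(C)C)cccc1C(C)C`: 6 nM
compound 2, `CCCCCCCCOC(=O)CC(=O)Nc1c(C(C)C)cccc1C(C)C`: 260 nM
compound 3, `Cc1cccc(C)c1NC(=O)CC(=O)Oc1c(C(C)C)cccc1C(C)C`: 210 nM

Compound 2 carries the highest number of the three in an assay on microsomes from intestine for inhibition of acyl-CoA:cholesterol acyltransferase (Oryctolagus cuniculus); on this read-out higher numbers stand for weaker inhibition and lower numbers for stronger inhibition. Compound 3 sits within the scatter of compound 2, so no order between those two can be read from these numbers. For the measured compounds named here, compound 1, on the other hand, gives a number well beyond the scatter below compound 2, with a longer and branched chain on the ester oxygen; the two differ in more than one place, so no single step is drawn from them.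

Compound 4, `CC(C)c1cccc(C(C)C)c1NC(=O)CC(=O)O`, has not yet been measured in this assay. It differs from compound 2 in one place: hydrogen in place of octyl on an oxygen next to a carbonyl group. Across the measured set, the ester chain is present in every compound, and the only large gap observed runs toward the longer chain of compound 1, away from compound 4. The expectation is therefore a step of a 31-fold higher number from compound 2 to compound 4 (1.49 log units; beyond the scatter) from compound 2 to compound 4, well beyond the scatter and toward weaker inhibition, with a real chance that the read-out reaches only a limit. Compound 4 is expected to give 8000 nM, within a range of 1500 nM to 40000 nM.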

Compound 4, half-maximal inhibitory concentration: > 5000 nM
Compound 4: only a limit was reported; the forecaster's own chance of this, stated with the estimate: 35%; the middle value lies beyond the limit too.
By their numbers in this assay, from the lowest: compound 1; then compounds 3 and 2 (each within the scatter of the next). At a limit, above all of these: compound 4.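

In this assay, hydrogen in place of octyl on an oxygen next to a carbonyl group gives an at least 19-fold higher number from compound 2 to compound 4 (1.28 log units; beyond the scatter). For the compounds shown here, this is the first step that can be read in one place, and it shows that inhibition at this position depends on what the oxygen carries: octyloxy to hydroxy costs a large part of it. The value of compound 4 is a limit and not a number: the limit of > 5000 nM in this assay, at which 1 of the 4 values shown sits.

The compounds shown leave open how much of this step belongs to the length of the chain and how much to the ester itself, which a methyl or butyl chain on that oxygen would separate. Also open, on these data alone, is whether a longer unbranched chain, such as dodecyl, goes further than octyl on the same core.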